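Methoxy for methyl on the side chain of compound 3

The source may report more compounds than this note shows. Statements on the series, on what has been measured and on what is new or still open speak of the compounds shown alone.

In a functional assay (plasma) with Oryctolagus cuniculus as the target (a lower number here means a stronger inhibitor, a higher number a weaker inhibitor), compound 1 `Cc1nc2cnccc2n1CC1CCN(C(=O)CNC(c2ccccc2)c2ccccc2)CC1` gives 13 nM and compound 2 `Cc1nc2cnccc2n1C1CCN(C(=O)CC(c2ccccc2)c2ccccc2)CC1` gives 100 nM while compound 3 `CC/C(=C\C(=O)N1CCC(Cn2c(C)nc3cnccc32)CC1)c1ccccc1` gives 13 nM and so stands level with compound 1, the pair sharing the lowest number of the three. Compound 4 `COC/C(=C\C(=O)N1CCC(Cn2c(C)nc3cnccc32)CC1)c1ccccc1` differs from compound 3 in one place, with methoxy in place of methyl on a saturated chain carbon bound to a double-bonded chain carbon. Among the measured compounds shown here, no measured pair shows what this change does, so the expectation is loose. The step expected in this assay (a 1.4-fold higher number from compound 3 to compound 4 (0.14 log units; within the scatter)) is small, toward a slightly higher number and not beyond the scatter. The estimate for compound 4 is 18 nM (expected range 6 nM to 55 nM).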

Compound 4, half-maximal inhibitory concentration: 18 nM
Beside the measured number, compound 4's estimate shows no gap at the digits printed, within the range that was stated.
By their numbers in this assay, from the lowest: compounds 1, 3 and 4 (each within the scatter of the next); then compound 2.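

In this assay, going from methyl to methoxy on a saturated chain carbon bound to a double-bonded chain carbon gives a 1.4-fold higher number from compound 3 to compound 4 (0.14 log units; within the scatter) and so stays within the scatter. At this place the chain can therefore carry an oxygen, and with it a hydrogen-bond acceptor, while compound 3 and compound 4 remain indistinguishable in this measurement. Nothing shown here offers an explanation for this result. On these data alone, whether the same place also tolerates an amine, a carboxylic acid or a longer chain remains open.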